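Vinyl Sulfones: Changing the Pyridyl Attachment Point

This account rests on a few compounds, and the source may have more. Where it says the series, first, only, none or still open, it means among the compounds named here.

compound 1 `COc1ccc(S(=O)(=O)/C=C/c2ccccn2)cc1` gives > 10000 nM
compound 2 `COc1ccc(S(=O)(=O)/C=C/c2ncccc2Cl)cc1` gives 347 nM

Both measurements come from an assay on U2OS cells for activation of nuclear factor erythroid 2-related factor 2 (Homo sapiens), read by chemiluminescence, with a stated time of 6 h; on this read-out lower numbers stand for an effect already at smaller amounts and higher numbers for an effect only at larger amounts of compound. Compound 1 stands only at a limit of this assay, not at a number, and so its place among the values shown is known just as being at that limit. Compound 2 sits at a measured number. Within the data shown here, the single measured step, an at least 28-fold lower number from compound 1 to compound 2 (1.45 log units; beyond the scatter), is large, but its true size is open because of the limit of > 10000 nM in this assay, at which 1 of the 2 values shown sits, on the side of compound 1.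

Compound 3 `COc1ccc(S(=O)(=O)/C=C/c2ccncc2)cc1` has not yet been measured. It differs from compound 1 by pyridin-4-yl in place of pyridin-2-yl on a double-bonded chain carbon bound to a double-bonded chain carbon. Among the measured compounds shown here, no measured step concerns a change of this kind; the step from compound 1 to compound 2 changes another part of the molecule and tells nothing about the attachment of the pyridyl ring. For the measured compounds named here, with compound 1 at a limit and no step bearing on the change, no movement beyond the scatter is expected, though the direction stays open. Compound 3 is therefore estimated at 7000 nM in this assay, within a range from 1500 nM to 30000 nM. The expected step is an at least 1.4-fold lower number from compound 1 to compound 3 (0.15 log units; that floor lies within the scatter).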

Compound 3, half-maximal effective concentration: 1200 nM
For compound 3 the middle estimate is 5.8-fold (0.77 log units) above the measured one; measured number outside the range, below it.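

In this assay, exchanging pyridin-2-yl for pyridin-4-yl gives an at least 8.3-fold lower number from compound 1 to compound 3 (0.92 log units; beyond the scatter), so the way the pyridyl ring is attached matters on its own, even though the two compounds hold the same atoms, joined differently. The earlier step, an at least 28-fold lower number from compound 1 to compound 2 (1.45 log units; beyond the scatter), had shown a change only on an aromatic carbon, with chloro in place of hydrogen, and so it said nothing about the attachment of the ring; two different single changes are now seen to lead to a lower number. The true size of the new step stays open, and the number for compound 3 can be read only against a limit of the assay: the limit of > 10000 nM in this assay, at which 1 of the 3 values shown sits.

The compounds shown leave open whether a phenyl ring in place of pyridin-4-yl, on a double-bonded chain carbon bound to a double-bonded chain carbon, would keep the lower number, which would test whether the ring nitrogen is needed at all. They also leave open whether chloro or an amine on the pyridin-4-yl ring would lower the number further, and they give no reason for the difference between pyridin-2-yl and pyridin-4-yl.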